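The source may hold more compounds than are shown below. What is called first, only, known or untested is meant among the compounds shown, and "the series" means these compounds.

Three compounds have numbers in a functional assay on PC-3 cells (Homo sapiens) for cytotoxicity, read by MTT assay, with a stated time of 48 h; a higher number here means a weaker inhibitor, a lower number a stronger inhibitor. Compound 1 `CCC(=O)N1N=C(C)CC1c1cc(Br)ccc1O` gives 37800 nM, compound 2 `O=c1oc2ccccc2cc1C1=NN(S(=O)(=O)c2ccc([N+](=O)[O-])cc2)C(c2ccccc2)C1` gives 46600 nM, and compound 3 `Cc1ccc(S(=O)(=O)N2N=C(c3cc4ccccc4oc3=O)CC2c2ccccc2)cc1` gives 48600 nM. The number of compound 3 is the highest of the three, yet both others lie within the scatter of it, so no order can be read. Among the measured compounds shown here, the single one-point step, a 1.0-fold higher number from compound 2 to compound 3 (0.02 log units; within the scatter), alters only an aromatic substituent and leaves the number unmoved. Compound 4 `CN1CCN(CC(=O)N2N=C(c3cc4ccccc4oc3=O)CC2c2ccccc2)CC1` differs from compound 3 elsewhere: ((4-methylpiperazin-1-yl)methyl)carbonyl in place of (4-methylphenyl)sulfonyl on an amine nitrogen in a ring. For the measured compounds named here, no measured step touches the amine nitrogen in a ring, so nothing supports a direction. For compound 4 the expected step is a 1.0-fold lower number from compound 3 to compound 4 (0.01 log units; within the scatter), nothing beyond the scatter. Compound 4 is estimated at 48000 nM, ranging from 15000 nM to 150000 nM.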

Compound 4, half-maximal inhibitory concentration: 25800 nM
The estimate for compound 4 lay 1.9-fold (0.27 log units) above the measured number; the range from low to high includes it.
By their numbers in this assay, from the lowest: compounds 4, 1, 2 and 3 (each within the scatter of the next).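

Among the compounds shown here, the first step at the amine nitrogen in a ring, in this assay, is a 1.9-fold lower number from compound 3 to compound 4 (0.28 log units; within the scatter), with ((4-methylpiperazin-1-yl)methyl)carbonyl in place of (4-methylphenyl)sulfonyl. This position therefore takes two groups of equal heavy-atom count, one with an aromatic ring of carbon only and one with a non-aromatic ring with hetero atoms, without a step beyond the scatter. No separate measurement bears on this result. On these data alone, whether an acetyl group or a longer chain ending in a morpholine at this nitrogen would give a step beyond the scatter remains open.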